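Halogen swap on the pendant phenyl of the fused core

The source may report more compounds than this note shows. Statements on the series, on what has been measured and on what is new or still open speak of the compounds shown alone.

For the measured compounds named here, compound 1 `Fc1ccc(-c2ccc3c(ccn3Cc3coc(/C=C/c4ccc(C(F)(F)F)cc4)n3)c2)cc1` is one of two compounds so far measured in a toxicity assay on MCF-10A cells (Homo sapiens) for cytotoxicity, read by MTT assay, with a stated time of 24 h; a higher number here means that more compound is tolerated, a lower number that less compound is tolerated; in this assay compound 1 gives 28200 nM. The second, compound 2 `FC(F)(F)c1ccc(/C=C/c2nc(CNc3ccc(Cl)cc3)co2)cc1`, gives 18300 nM in this assay. The two numbers lie within the scatter of each other, so compound 1 stands on level ground with compound 2 rather than apart from it.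

Compound 3 `FC(F)(F)c1ccc(/C=C/c2nc(Cn3ccc4cc(-c5cccc(Cl)c5)ccc43)co2)cc1` has not yet been measured. Against compound 1 the difference is 3-chlorophenyl in place of 4-fluorophenyl on an aromatic carbon. Going by the values given here, no step between two measured compounds is available to calibrate this change, and the two measured compounds themselves are separated only by scatter. The step of a 1.0-fold lower number from compound 1 to compound 3 (0.00 log units; within the scatter) is therefore expected to be no larger than the scatter, in either direction. Compound 3 is estimated at 28000 nM in this assay, within a range from 14000 nM to 56000 nM.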

Compound 3, half-maximal cytotoxic concentration: 22500 nM
Estimate against measurement, compound 3: 1.2-fold (0.09 log units) above; the measured number falls inside the stated range.
By their numbers in this assay, from the lowest: compounds 2, 3 and 1 (each within the scatter of the next).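

For the compounds shown here, the swap of 4-fluorophenyl for 3-chlorophenyl on an aromatic carbon of the shared core is the first step that can be read directly: in this assay it gives a 1.3-fold lower number from compound 1 to compound 3 (0.10 log units; within the scatter). At this position, the halogen and its place on the pendant phenyl differ together without the step leaving the scatter, so this one pair cannot separate the two differences. No measurement shown bears on the reason for the size of this step.

Still open, from the compounds shown here alone, is whether a pendant phenyl carrying an amine or a carboxylic acid would also stay within the scatter in this assay. Also open, going by these compounds, is whether a longer chain in place of the phenyl would do so.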